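Shared core: ring substituent moved from hydroxy to methoxy

The source may hold more compounds than are shown below. What is called first, only, known or untested is meant among the compounds shown, and "the series" means these compounds.

Of the compounds shown here, three on the shared core have been measured in an assay on CHO cells for inhibition of Glucagon receptor (Homo sapiens); on this read-out lower numbers stand for stronger inhibition and higher numbers for weaker inhibition. Compound 1 `CCCCCc1c(C(C)C)nc(C(C)C)c(CO)c1-c1ccccc1F` gives 9000 nM; compound 2 `CCCCCc1c(C(C)C)nc(C(C)C)c(CO)c1-c1cccc(O)c1` gives 6000 nM; compound 3 `CCCCCc1c(C(C)C)nc(C(C)C)c(CO)c1-c1ccccc1O` gives 500 nM, the lowest number of the three, with a 12-fold lower number from compound 2 to compound 3 (1.08 log units; beyond the scatter) and an 18-fold lower number from compound 1 to compound 3 (1.26 log units; beyond the scatter). The step of a 1.5-fold lower number from compound 1 to compound 2 (0.18 log units; within the scatter) stays within the scatter. Compound 4 `CCCCCc1c(C(C)C)nc(C(C)C)c(CO)c1-c1cccc(OC)c1` differs from compound 3 by 3-methoxyphenyl in place of 2-hydroxyphenyl on an aromatic carbon. Within the data shown here, the measured step that bears on this is a 12-fold lower number from compound 2 to compound 3 (1.08 log units; beyond the scatter), which would be run backwards; the hydroxy group is also removed, and no measured pair sets methoxy against hydroxy on this ring. A move back toward the numbers of compound 2 and compound 1 is therefore expected. The expected step is a 14-fold higher number from compound 3 to compound 4 (1.15 log units; beyond the scatter). Compound 4 is expected at 7000 nM, in the range 2500 nM to 20000 nM.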

Compound 4, half-maximal inhibitory concentration: 48000 nM
Estimate against measurement, compound 4: 6.9-fold (0.84 log units) below, outside the stated range (above it).
By their numbers in this assay, from the lowest: compound 3; then compounds 2 and 1 (each within the scatter of the next); then compound 4.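

In this assay, methyl in place of hydrogen on the oxygen gives an 8.0-fold higher number from compound 2 to compound 4 (0.90 log units; beyond the scatter), so this aromatic substituent is sensitive to a change at the oxygen itself and not only to where the hydroxy group sits. The 3-methoxyphenyl also falls behind 2-fluorophenyl, with a 5.3-fold higher number from compound 1 to compound 4 (0.73 log units; beyond the scatter), and a 96-fold higher number from compound 3 to compound 4 (1.98 log units; beyond the scatter) is the widest step in the series. No evidence on hand accounts for these steps.

From the compounds shown here alone, what methyl on the oxygen of 2-hydroxyphenyl would do remains open. So does the effect of an amino group in place of that hydroxy.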